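Side-chain swap on the ethenyl arm: compound 3 to compound 4

This account rests on a few compounds, and the source may have more. Where it says the series, first, only, none or still open, it means among the compounds named here.

Values in an ADME assay on BJ cells (Homo sapiens) for cytotoxicity, with a stated time of 72 h (on this read-out lower numbers stand for an effect already at smaller amounts and higher numbers for an effect only at larger amounts of compound), each one a limit:
- compound 1 `C=C[C@@](C)(/C=C/c1ccc(O)c(C=O)c1)CCC=C(C)C`: > 36600 nM
- compound 2 `C=C[C@@](C)(/C=C/c1ccc(O)c(/C=C/C(=O)c2ccccc2)c1)CCC=C(C)C`: > 20000 nM
- compound 3 `C=C[C@@](C)(/C=C/c1ccc(O)c(/C=C/C(N)=O)c1)CCC=C(C)C`: > 36600 nM

Compound 3 stands at the limit of > 36600 nM in this assay, at which 2 of the 3 values shown sit. Compound 2 stands at the limit of > 20000 nM in this assay, at which 1 of the 3 values shown sits. Among the measured compounds shown here, no compound has yet given a number.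

The next compound is compound 4 `C=C[C@@](C)(/C=C/c1ccc(O)c(/C=C/c2ccc(F)cc2)c1)CCC=C(C)C`. The change from compound 3 is 4-fluorophenyl in place of carbamoyl on a double-bonded chain carbon bound to a double-bonded chain carbon.

For the measured compounds named here, two measured steps bear on this arm. Going by the values given here, the first is a step that the two limits leave unreadable from compound 1 to compound 3, and the second is a step that the two limits leave unreadable from compound 2 to compound 3. Neither gives a size, so no direction can be drawn from them, and no step beyond the scatter is expected in this assay. Compound 2 also carries an aromatic ring on this arm and still gave only the limit > 20000 nM. The expected change is an at least 1.2-fold lower number from compound 3 to compound 4 (0.08 log units; that floor lies within the scatter). For compound 4 the estimated value is 30000 nM, with an expected range from 12000 nM to 60000 nM.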

Compound 4, half-maximal effective concentration: > 36600 nM
Compound 4 was reported as a limit; the forecaster's own chance of this, stated with the estimate: 70%; at least 1.2-fold (0.08 log units) between middle value and limit.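

Compound 4 is again a limit, > 36600 nM. Among the compounds shown here, compound 1, compound 2 and compound 3 are also limits, so no step involving compound 4 can be read. The compounds shown leave open whether any swap on the ethenyl arm moves this read-out, and where any of the four would give an actual number.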